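A few compounds are considered here, and "the series" means these few. Any claim that something is new, unique, unknown or untested is made for them only; others in the source may bear on it.

Compound 2, `ONCCCc1c[nH]c2ccc(F)cc12`, gives 11 nM in an assay on isolated protein (urine) for inhibition of Myeloperoxidase (Homo sapiens), with a stated time of 5 min (on this read-out higher numbers stand for weaker inhibition and lower numbers for stronger inhibition), the lowest of the two numbers at hand. Among the measured compounds shown here, its only measured neighbour is compound 1, `NC(=O)CCCCc1c[nH]c2ccc(F)cc12`, which in this assay gives 39 nM; the move between them is a 3.5-fold lower number from compound 1 to compound 2 (0.55 log units; beyond the scatter), a modest step beyond the scatter that separates the two amide and hydroxyamino compounds. Compound 3, `CCNC(=O)CCCc1c[nH]c2ccc(F)cc12`, has not yet been measured. It differs from compound 2 by ethylcarbamoyl in place of hydroxyamino on a saturated chain carbon, three bonds along the chain from an aromatic carbon, which, cut one bond further out, reads (hydroxyamino)methyl to (ethylcarbamoyl)methyl. For the measured compounds named here, the only relevant step runs in the opposite direction, from an amide to the hydroxyamino group, and gains potency; reversing it back to an amide, now ethyl-substituted and one chain atom shorter than in compound 1, is expected to cost a comparable amount. Compound 3 is therefore estimated at 80 nM, within 25 nM to 260 nM, a step of a 7.3-fold higher number from compound 2 to compound 3 (0.86 log units; beyond the scatter).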

Compound 3, half-maximal inhibitory concentration: 182 nM
Estimate against measurement, compound 3: 2.3-fold (0.36 log units) below; low and high end bracket the measured number.
By their numbers in this assay, from the lowest: compound 2; then compound 1; then compound 3.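

In this assay, a 17-fold higher number from compound 2 to compound 3 (1.22 log units; beyond the scatter) is a large loss on a saturated chain carbon, three bonds along the chain from an aromatic carbon, so this position responds strongly to what is placed there. The a 4.7-fold higher number from compound 1 to compound 3 (0.67 log units; beyond the scatter) adds that the two amide compounds are not equivalent: compound 3, with ethylcarbamoyl, is weaker than compound 1, with carbamoylmethyl, leaving compound 2 and its hydroxyamino group the strongest of the three. Nothing available accounts for either step.

The compounds shown leave open how far the loss belongs to the ethyl group itself, since no compound carries an unsubstituted carbamoyl or a methylcarbamoyl group at this place. They also leave open how a carboxylic acid, a primary amine or a longer chain ending in hydroxyamino would read here.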